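A few compounds are considered here, and "the series" means these few. Any claim that something is new, unique, unknown or untested is made for them only; others in the source may bear on it.

Measured in a physicochemical assay for solubility, read by HPLC, measured as thermodynamic solubility, with a stated time of 4 h, at pH 6.8; on this read-out lower numbers stand for lower solubility and higher numbers for higher solubility:

compound 1 `Cn1c(COc2cccc(C(=O)O)c2)nc2ccc(Oc3ccc4c(c3)CCC4)nc21`: 4.3 ug/mL
compound 2 `Cn1c(COc2cccc(C(=O)O)c2)nc2cnc(Oc3ccc4c(c3)OCC4)cc21`: 79 ug/mL
compound 3 `Cn1c(COc2cccc(C(=O)O)c2)nc2ccc(Oc3ncccc3Cl)cc21`: 15 ug/mL

On these values compound 3 stands second highest of the three. Its nearest neighbour is compound 1, which sits lower by a gap beyond the scatter; the furthest is compound 2, which sits higher by a larger gap, also beyond the scatter. For the measured compounds named here, none of the three measured compounds differ from one another in a single place, so the set offers no step between measured compounds from which to size a single structural change.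

Compound 4 `Cc1cccnc1Oc1ccc2nc(COc3cccc(C(=O)O)c3)n(C)c2c1` has not been measured. Relative to compound 3 the change is methyl in place of chloro on an aromatic carbon. Going by the values given here, the measured compounds say nothing about an exchange of this kind, and with no comparable step on record the working assumption is conservative: in this assay a step of no change at the digits printed from compound 3 to compound 4 (within the scatter) is expected, that is, a change no larger than the scatter, with the direction left open. Compound 4 is therefore estimated at 15 ug/mL, with a range from 6 ug/mL to 40 ug/mL that allows for a modest move either way.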

Compound 4, solubility: 37 ug/mL
The estimate for compound 4 lay 2.5-fold (0.39 log units) below the measured number; measured number inside the range.
By their numbers in this assay, from the lowest: compound 1; then compound 3; then compound 4; then compound 2.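

In this assay, for the compounds shown here, the exchange of 3-chloropyridin-2-yl for 3-methylpyridin-2-yl gives a 2.5-fold higher number from compound 3 to compound 4 (0.39 log units; beyond the scatter) and provides the first step that sizes a single structural change. It is a modest step but lies beyond the scatter, so this aromatic carbon, two atoms from the ring nitrogen, is a place where the read-out responds to a change of one heavy atom, even though neither group brings a ring, a hydrogen-bond donor or acceptor, or a net charge. Nothing on hand accounts for the size or direction of this step.

With only methyl and chloro shown at this carbon, the compounds leave open how other groups there, such as fluoro, methoxy, trifluoromethyl or an amine, would read in this assay and whether any of them would stand beyond methyl. They also leave open whether methyl in place of chloro gives a step of similar size and the same direction on a different core or at another aromatic carbon, since this single pair sets no general rule.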